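The compounds below may be only part of what the source reports. "The series", "measured", "known", "first", "only" and "open" are said of these compounds alone.

Series notes. Compound 1 `COc1ccc(-c2[nH]c3ccccc3c2/C=C(\C#N)S(=O)(=O)c2ccccc2)cc1` was run in a functional assay on MDA-MB-468 cells (Homo sapiens) for inhibition, read by sulforhodamine B assay, with a stated time of 48 h; a higher number here means a weaker inhibitor of growth, a lower number a stronger inhibitor of growth. In this assay compound 1 shows only an assay limit, < 10 nM, so no number is known for it. Compound 1 sits at the limit of < 10 nM in this assay, at which 1 of the 2 values shown sits. Compound 2 `COc1ccc2[nH]c(-c3ccccc3)c(C=C(C#N)C#N)c2c1` gives 2100 nM in this assay; compound 2 and compound 1 differ in more than one place, so their two values are simply noted side by side. Compound 3 `COc1ccc(-c2[nH]c3ccc(OC)cc3c2/C=C(\C#N)S(=O)(=O)c2ccccc2)cc1` carries methoxy in place of hydrogen on an aromatic carbon, methoxy in place of hydrogen on an aromatic carbon. Among the compounds with values here, no measured step of this kind exists here, and the change is expected to move this assay little, if at all beyond the scatter. Compound 3 is estimated at 8 nM (range 2 nM to 30 nM), an expected step that the limit leaves unreadable from compound 1 to compound 3.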

Compound 3, concentration for 50% growth inhibition: 1300 nM
Beside the measured number, compound 3's estimate is 160-fold (2.21 log units) below it; measured number outside the range, above it.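

Within the data shown here, this carbon of the core is not a silent position: in this assay, methoxy in place of hydrogen gives an at least 130-fold higher number from compound 1 to compound 3 (2.11 log units; beyond the scatter), the first measured step. In this single pair, hydrogen gives the stronger growth inhibition. The full size of the step cannot be read, because compound 1 stands at an assay limit rather than at a number: the limit of < 10 nM in this assay, at which 1 of the 3 values shown sits.

The compounds shown leave open whether fluorine, methyl or hydroxy on this carbon would track hydrogen or methoxy. A single pair also cannot show whether the step holds with other groups elsewhere on the core.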